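Aryl Triazole Variants in a Cell Proliferation Assay

This account rests on a few compounds, and the source may have more. Where it says the series, first, only, none or still open, it means among the compounds named here.

Compound 1 `CCc1ccccc1-n1nncc1CN1C(=O)C2(C(C#N)=C(N)Oc3c(N)cc4nc5ccccc5nc4c32)c2ccccc21` gives 22900 nM.
Compound 2 `N#CC1=C(N)Oc2c(N)cc3nc4ccccc4nc3c2C12C(=O)N(Cc1cnnn1-c1ccccc1Br)c1ccccc12` gives 29200 nM.
Compound 3 `N#CC1=C(N)Oc2c(N)cc3nc4ccccc4nc3c2C12C(=O)N(Cc1cnnn1-c1c(F)cccc1F)c1ccccc12` gives only a limit, > 50000 nM.

The three measured compounds share one core and differ only in the aryl group on the triazole nitrogen. In an ADME assay on L02 cells (Homo sapiens) for antiproliferative activity, read by MTT assay, with a stated time of 48 h (a higher number here means a weaker inhibitor, a lower number a stronger inhibitor), compound 1 gives 22900 nM, and in this assay compound 2 gives 29200 nM. For compound 3 this assay reports no number but a limit, so compound 3 stands at the limit of > 50000 nM in this assay, at which 1 of the 3 values shown sits. The step of a 1.3-fold higher number from compound 1 to compound 2 (0.11 log units; within the scatter) changes little. The steps of an at least 2.1-fold higher number from compound 1 to compound 3 (0.33 log units; beyond the scatter) and an at least 1.7-fold higher number from compound 2 to compound 3 (0.23 log units; that floor lies within the scatter) both run toward the limit.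

Compound 4 `COc1ccc(OC)c(-n2nncc2CN2C(=O)C3(C(C#N)=C(N)Oc4c(N)cc5nc6ccccc6nc5c43)c3ccccc32)c1` differs from compound 3 in one place: 2,5-dimethoxyphenyl in place of 2,6-difluorophenyl on an aromatic nitrogen. The two steps into compound 3 bear on this change in reverse: each time the 2,6-difluorophenyl entered, the number rose. Going the other way, a number back near compounds 1 and 2 is plausible, though no measured compound shows how the 2,5-dimethoxyphenyl itself behaves. The step of an at least 1.2-fold lower number from compound 3 to compound 4 (0.09 log units; that floor lies within the scatter) is therefore expected to be modest and downward, if any. Compound 4 is expected at 40000 nM, in a range from 15000 nM to 100000 nM, with a fair chance that this assay again reports only a limit.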

Compound 4, half-maximal inhibitory concentration: > 50000 nM
Compound 4 ended at the assay's limit; the forecaster's own chance of this, stated with the estimate: 40%; middle value at least 1.2-fold (0.09 log units) away from the limit.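

In this assay compound 4 joins compound 3 at a limit rather than a number, so a second aryl group on the triazole nitrogen now gives no readable value: the limit of > 50000 nM in this assay, at which 2 of the 4 values shown sit.

The 2,5-dimethoxyphenyl group, which carries hydrogen-bond acceptors that the 2,6-difluorophenyl group lacks, does not bring the number back: against the 2-ethylphenyl group the change gives an at least 2.1-fold higher number from compound 1 to compound 4 (0.33 log units; beyond the scatter), and against the 2-bromophenyl group it gives an at least 1.7-fold higher number from compound 2 to compound 4 (0.23 log units; that floor lies within the scatter). The step between the two compounds at the limit cannot be read, so those two groups stay unranked.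

On these data alone, whether an aryl group carrying an amine or a carboxylic acid would give a number in this assay or another limit remains open. As far as these compounds go, how far compound 3 and compound 4 actually lie past the limit also remains open.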